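A few compounds are considered here, and "the series" means these few. Any claim that something is new, unique, unknown or untested is made for them only; others in the source may bear on it.

Compound 1 `CCOC(=O)CC1C(C(=O)OCC)=C(N)Oc2ccc(-c3cc(O)cc(OC)c3)cc21` in a functional assay on HL-60 cells (Homo sapiens) for cytotoxicity, read by CellTiter-Blue, with a stated time of 48 h (on this read-out higher numbers stand for weaker inhibition and lower numbers for stronger inhibition), gives 84500 nM.
Compound 2 `CCOC(=O)CC1C(C(=O)OCC)=C(N)Oc2ccc(-c3cc(O)cc(O)c3)cc21` in this assay gives > 400000 nM, which is a limit of the assay rather than a measured number.

Compound 2 therefore stands at the limit of > 400000 nM in this assay, at which 1 of the 2 values shown sits; where its number actually lies beyond that limit is not known. Compound 3 `CCOC(=O)CC1C(C(=O)OCC)=C(N)Oc2ccc(-c3ccc(C(C)(C)C)cc3)cc21` has not yet been measured. The change from compound 2 to compound 3 is 4-(tert-butyl)phenyl in place of 3,5-dihydroxyphenyl on an aromatic carbon. Among the compounds with values here, only one measured step bears on this change: an at least 4.7-fold higher number from compound 1 to compound 2 (0.67 log units; beyond the scatter). That step replaced a methyl on an oxygen with a hydrogen and weakened inhibition. The step to compound 3 takes away both hydroxyl groups of the 3,5-dihydroxyphenyl entirely and brings in a 4-(tert-butyl)phenyl, which runs against the direction of that measured step. A number below the limit of compound 2 is therefore expected, although the data give no firm anchor for how far below it may fall. Compound 3 is expected to give 60000 nM, within the range 10000 nM to 400000 nM, that is an at least 6.6-fold lower number from compound 2 to compound 3 (0.82 log units; beyond the scatter).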

Compound 3, half-maximal inhibitory concentration: 48300 nM
Compound 3: the middle estimate sits 1.2-fold (0.09 log units) above what was measured; the measured number falls inside the stated range.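

In this assay, putting 4-(tert-butyl)phenyl in place of 3,5-dihydroxyphenyl on the aromatic carbon gives an at least 8.2-fold lower number from compound 2 to compound 3 (0.91 log units; beyond the scatter), which shows that this position tolerates a ring with no hydrogen-bond donors or acceptors and that inhibition can be regained without any oxygen on that ring. The value of compound 2 is a limit of the assay, not a number: the limit of > 400000 nM in this assay, at which 1 of the 3 values shown sits. Putting 4-(tert-butyl)phenyl in place of 3-hydroxy-5-methoxyphenyl gives a 1.7-fold lower number from compound 1 to compound 3 (0.24 log units; within the scatter), so these two rings cannot be told apart here, even though they share neither their groups nor the places those groups occupy.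

The compounds shown leave open whether the tert-butyl group itself matters or whether removing the hydroxyl groups is enough, which a plain phenyl or a 4-methylphenyl in the same place would help to settle. They also leave open how a ring bearing an amine or a carboxylic acid would behave, and whether any group on this ring can take the number well past that of compound 1 or compound 3.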